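Sulfonyl in place of allylcarbamoyl on the core nitrogen

This account rests on a few compounds, and the source may have more. Where it says the series, first, only, none or still open, it means among the compounds named here.

Measured so far:
compound 1 `C=CCNC(=O)n1c(-c2ccc(OC)cc2)cc(=O)c2c(OC)cc(OC)cc21`: > 20000 nM
compound 2 `COc1ccc(-c2cc(=O)c3c(OC)cc(OC)cc3n2S(=O)(=O)c2cccc([N+](=O)[O-])c2)cc1`: > 39600 nM
compound 3 `COc1ccc(-c2cc(=O)c3c(OC)cc(OC)cc3n2S(=O)(=O)c2c(F)c(F)c(F)c(F)c2F)cc1`: > 34400 nM

In a functional assay on HepG2 cells (Homo sapiens) for antiproliferative activity, with a stated time of 72 h (a lower number here means that less compound is needed, a higher number that more compound is needed for the effect), compound 1 gives > 20000 nM, which is a limit of the assay and not a number. In this assay compound 2 likewise gives only a limit, > 39600 nM. Compound 3 also sits at a limit, > 34400 nM. Going by the values given here, all three values shown are limits, so compound 1 cannot be placed above or below the other two, and the one step between measured compounds, a step that the two limits leave unreadable from compound 2 to compound 3, is unreadable.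

Compound 4 `COc1ccc(-c2cc(=O)c3c(OC)cc(OC)cc3n2S(=O)(=O)c2ccc(C)cc2)cc1` differs from compound 1 in one place: (4-methylphenyl)sulfonyl in place of allylcarbamoyl on an aromatic nitrogen. The two measured compounds that carry a sulfonyl group on the same aromatic nitrogen, compound 2 and compound 3, both reached only a limit, the limit of > 39600 nM in this assay, at which 1 of the 3 values shown sits, and (the limit of > 34400 nM in this assay, at which 1 of the 3 values shown sits), and compound 1 itself reached only a limit, (the limit of > 20000 nM in this assay, at which 1 of the 3 values shown sits). Among the compounds with values here, no measured step bears on the change in a readable way; what the data show is that every variant of this core so far has stayed at a limit in this assay. For compound 4 it is therefore expected that a step that the limit leaves unreadable from compound 1 to compound 4 shows nothing beyond the scatter and that the estimate again lies at a limit. Compound 4 is estimated at 30000 nM, with a range of 10000 nM to 100000 nM.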

Compound 4, half-maximal effective concentration: > 44800 nM
Compound 4 gave a limit, no number; the forecaster's own chance of this, stated with the estimate: 80%; at least 1.4-fold (0.17 log units) between middle value and limit.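

In this assay compound 4 gives only a limit, as do compound 1, compound 2 and compound 3, so the steps joining compound 4 to those three cannot be read. The compounds shown leave open how far the group on the aromatic nitrogen of the shared core, or the aryl group on the sulfonyl sulfur, affects the read-out in this assay.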